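Three Methoxy Groups Give Way to a Single Fluorine

The source may hold more compounds than are shown below. What is called first, only, known or untested is meant among the compounds shown, and "the series" means these compounds.

Compound 2 `COc1cc(OC)c(OC)cc1/C=C/COC(=O)/C=C/c1ccc(OC)c(OC)c1` is the reference point here. In a functional assay on the whole organism (strain Kunming) with Mus musculus as the target, with a stated time of 0.5 h, at a dose of 300 mg/kg by the intraperitoneal route (a higher number here means a weaker effect of the compound at the dose given, a lower number a stronger effect), compound 2 gives 100%. Its neighbours share the same chain and ester and differ only in the substitution of the ring at the far end. Compound 1 `COc1cc(OC)c(OC)cc1/C=C/COC(=O)/C=C/c1ccc(OC)c(OC)c1OC` gives 100%, and compound 3 `COc1cc(OC)c(OC)cc1/C=C/COC(=O)/C=C/c1c(OC)ccc(OC)c1OC` gives 100%. Within the data shown here, the one step that can be read directly, no change at the digits printed from compound 1 to compound 2 (within the scatter), lies within the scatter, so compound 2 stands level with compound 1 and with compound 3 at the digits reported.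

The unmeasured compound 4 `COc1cc(OC)c(OC)cc1/C=C/COC(=O)/C=C/c1ccc(F)cc1` differs from compound 2 in this way: 4-fluorophenyl in place of 3,4-dimethoxyphenyl on a double-bonded chain carbon bound to a double-bonded chain carbon. That is a larger change than any among the measured compounds, all of which return the same read-out. Among the measured compounds shown here, only the step from compound 1 to compound 2 bears on it, and that step was flat. For the measured compounds named here, no measured compound lacks both methoxy groups on that ring, and none carries fluorine, so nothing in the data points to a shift in either direction. Since every measured compound sits at the same read-out, compound 4 is expected to do the same, with no change at the digits printed from compound 2 to compound 4 (within the scatter) expected to stay within the scatter. The estimate for compound 4 is 100%, ranging from 80% to 100%.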

Compound 4, a percentage reported as activity, at one dose (the size of the read-out at that dose, not a potency): 100%
Estimate against measurement, compound 4: no gap at the digits printed; the measured number falls inside the stated range.
By their numbers in this assay, from the lowest: compounds 1, 2, 3 and 4 (each within the scatter of the next).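

In this assay, among these compounds, the step of no change at the digits printed from compound 2 to compound 4 (within the scatter) extends what the earlier compounds showed: until now, the only step that could be read at this position on a double-bonded chain carbon bound to a double-bonded chain carbon was the exchange of a single methoxy group for hydrogen. Here the whole 3,4-dimethoxyphenyl group, with its 10 heavy atoms and 2 hydrogen-bond acceptors, gives way to 4-fluorophenyl, with 7 heavy atoms and 0 hydrogen-bond acceptors, and the read-out stays level, so this position tolerates a much larger exchange than the earlier step could show, and one that brings in fluorine for the first time. No supporting measurement bears on why the read-out holds level across this exchange.

All four compounds sit level, so the compounds shown do not reveal any group at this position that separates itself from the others in this assay. As far as these compounds go, it remains open whether an amine or a carboxylic acid on this aromatic ring, or a longer chain in place of the ring, would move the read-out at all.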